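The source may report more compounds than this note shows. Statements on the series, on what has been measured and on what is new or still open speak of the compounds shown alone.

Working notes on the series.

Of the compounds shown here, three have been measured in a functional assay on HepG2 cells (Homo sapiens) for inhibition, read by MTT assay, with a stated time of 72 h; on this read-out higher numbers stand for weaker inhibition and lower numbers for stronger inhibition. Compound 1, `O=C1O[C@H]([C@@H](O)Cn2ccc(NC(=O)c3ccccc3)nc2=O)C(OCc2ccccc2)=C1OCc1ccccc1`, gives 62200 nM. Compound 2, `NC1(CCn2cc(F)c(=O)[nH]c2=O)OC(=O)C(OCc2ccccc2)=C1OCc1ccccc1`, gives 42800 nM. Compound 3, `O=C1O/C(=C\Cn2ccc(NC(=O)c3ccccc3)nc2=O)C(OCc2ccccc2)=C1OCc1ccccc1`, gives 1980 nM. Compound 2 stands second highest of the three numbers; its value and that of compound 1 lie within the scatter of each other, so no order between them is claimed, while the value of compound 3 lies well beyond the scatter and is the lowest of the set.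

The next compound to be measured in this assay is compound 4, `Nc1ccn(CCC2(N)OC(=O)C(OCc3ccccc3)=C2OCc2ccccc2)c(=O)n1`. It differs from compound 2 as follows: a group of 8 heavy atoms (4 carbon, 3 nitrogen, 1 oxygen; one six-membered aromatic ring with 2 hetero atoms) in place of a group of 9 heavy atoms (4 carbon, 2 nitrogen, 2 oxygen, 1 fluorine; one six-membered aromatic ring with 2 hetero atoms), on a saturated chain carbon, two bonds along the chain from a saturated ring carbon. Among the compounds with values here, no measured pair in the set carries this change on its own, so the size of the step has no direct precedent here. Compound 4 keeps the shared core of compound 2 and the same point of attachment on the chain; the expectation is therefore a step no larger than the scatter, with no clear direction, giving an estimated step of a 1.1-fold lower number from compound 2 to compound 4 (0.03 log units; within the scatter). For compound 4 in this assay the estimate is 40000 nM, with a range from 15000 nM to 100000 nM.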

Compound 4, half-maximal inhibitory concentration: > 100000 nM
Compound 4: no number, only a limit; the forecaster's own chance of this, stated with the estimate: 15%; at least 2.5-fold (0.39 log units) between middle value and limit.
By their numbers in this assay, from the lowest: compound 3; then compounds 2 and 1 (each within the scatter of the next). At a limit, above all of these: compound 4.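

Within the data shown here, the first step in the set at this place, on a saturated chain carbon, two bonds along the chain from a saturated ring carbon, is an at least 2.3-fold higher number from compound 2 to compound 4 (0.36 log units; beyond the scatter), so exchanging the group of 9 heavy atoms for the group of 8 heavy atoms is not neutral on this read-out. In this assay compound 4 gives > 100000 nM, which is a limit of the assay and not a number, so the step has a lower bound and no measured size. Compound 4 is the one compound of the set that reaches this limit: the limit of > 100000 nM in this assay, at which 1 of the 4 values shown sits.

The exchange alters several atoms at once, and the compounds shown do not tell which of those alterations carries the step. Also open, from the compounds shown here alone, is how a longer chain would read with either group.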